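Adding an isobutyl group to compound 1

The source may report more compounds than this note shows. Statements on the series, on what has been measured and on what is new or still open speak of the compounds shown alone.

- compound 1 `CC[C@@H]1C(=O)N(C)c2cnc(-n3ccc4cc(C(N)=O)ccc43)nc2N1C1CCCC1` gives 3090 nM as its value
- compound 2 `CCCCNS(=O)(=O)c1ccc(Nc2ncc3c(n2)N(c2ccn(C)n2)C(CC)C(=O)N3C)cc1` gives 3750 nM as its value

Both values come from a functional assay on Huh-7 cells (Homo sapiens) for antiproliferative activity, read by CCK-8 assay, with a stated time of 72 h (on this read-out higher numbers stand for weaker inhibition of growth and lower numbers for stronger inhibition of growth), and lie within the usual scatter of each other, so compound 1 stands level with compound 2 and the two cannot be ranked. Among the measured compounds shown here, the two compounds differ in more than one place, so the measured data contain no single-change step to serve as a guide.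

Compound 3 `CC[C@@H]1C(=O)N(C)c2cnc(-n3ccc4cc(C(=O)NCC(C)C)ccc43)nc2N1C1CCCC1` has not yet been measured in this assay and keeps the core of compound 1. The structural change is isobutyl in place of hydrogen on an amide-type nitrogen. For the measured compounds named here, with no measured step to draw on, the starting point is compound 1 at 3090 nM and only a small move towards weaker inhibition of growth is expected in this assay at most, with wide uncertainty in either direction. The estimated step is a 1.5-fold higher number from compound 1 to compound 3 (0.16 log units; within the scatter) and it is expected to stay close to the scatter. The expected value for compound 3 is 4500 nM with an estimated range of 1300 nM to 15000 nM on this reasoning.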

Compound 3, concentration for 50% growth inhibition: "not active" (no number reported)
Nothing numeric was reported for compound 3; the estimate stays without a comparison.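

In this assay, among the compounds shown here, compound 3 was reported only as not active, without a number, so no step from compound 1 to compound 3 can be read. Nothing measured here offers an explanation for this result. The compounds shown leave open how far isobutyl in place of hydrogen on the amide-type nitrogen shifts growth inhibition.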